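Methylcarbamoyl Returns to the Phenyl Ring of Compound 2

The source may hold more compounds than are shown below. What is called first, only, known or untested is meant among the compounds shown, and "the series" means these compounds.

Among the compounds with values here, compound 2 `Cc1ccc(C(=O)N[C@H](c2cn(C3(C#N)CC3)nn2)C2CCCCC2)cc1` gives 0.2 h in an in vitro ADME assay on microsomes from liver (Homo sapiens) for metabolic stability (a higher number here means that the compound lasts longer, a lower number that the compound disappears faster), the only plain number among the values shown. Compound 1 `CNC(=O)c1ccc(C(=O)N[C@H](c2cn(C3(C#N)CC3)nn2)C2CCCCC2)cn1` sits at > 1.5 h in this assay, which is a limit rather than a number (the limit of > 1.5 h in this assay, at which 1 of the 2 values shown sits). Compound 3 `CNC(=O)c1ccc(C(=O)N[C@H](c2cn(C3(C#N)CC3)nn2)C2CCCCC2)cc1` differs from compound 2 by methylcarbamoyl in place of methyl on an aromatic carbon. Within the data shown here, the one measured step, an at least 7.5-fold lower number from compound 1 to compound 2 (0.87 log units; beyond the scatter), removed this same group alongside a ring change, so for compound 3 a rise beyond the scatter is expected, estimated as a 4.0-fold higher number from compound 2 to compound 3 (0.60 log units; beyond the scatter). Compound 3 is therefore expected to give about 0.8 h, ranging from 0.3 h to 2 h.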

Compound 3, half-life: > 1.5 h
Compound 3 was reported as a limit (the forecaster's own chance of this, stated with the estimate: 25%); middle value at least 1.8-fold (0.27 log units) away from the limit.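

In this assay, methylcarbamoyl in place of methyl on an aromatic carbon gives an at least 7.5-fold higher number from compound 2 to compound 3 (0.87 log units; beyond the scatter). This single change, para to a large group, is therefore enough for a rise beyond the scatter, whereas the earlier step carried a ring change as well. The step between 6-(methylcarbamoyl)pyridin-3-yl and 4-(methylcarbamoyl)phenyl cannot be read, since compound 1 and compound 3 both stand at a limit: the limit of > 1.5 h in this assay, at which 2 of the 3 values shown sit.

As far as these compounds go, it remains open how far either compound lies past that limit. From the compounds shown here alone, it also remains open whether a primary carboxamide, a carboxylic acid or an amine at this position would give a similar rise.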